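Exchanging the Aromatic Ring at the Chain End

The source may hold more compounds than are shown below. What is called first, only, known or untested is meant among the compounds shown, and "the series" means these compounds.

Compound 1 `COC1=C(C)C(=O)/C(=C(O)/C=C/c2cccc(OC)c2)C(=O)C1(C)C` and compound 2 `COC1=C(C)C(=O)/C(=C(O)/C=C/c2ccc(O)cc2)C(=O)C1(C)C` share one core and differ only in the ring carried on the chain. In a functional assay on 1A9 cells (Homo sapiens) for cytotoxicity (on this read-out higher numbers stand for an effect only at larger amounts of compound and lower numbers for an effect already at smaller amounts), compound 1 gives 2.9 ug/mL, and compound 2 gives 2.9 ug/mL. The step of no change at the digits printed from compound 1 to compound 2 (within the scatter) was flat, so compound 2 stands level with compound 1. Compound 3 `COC1=C(C)C(=O)/C(=C(O)/C=C/c2ccco2)C(=O)C1(C)C` carries furan-2-yl in place of 4-hydroxyphenyl on a double-bonded chain carbon bound to a double-bonded chain carbon. Going by the values given here, only that single measured step, a swap of the same ring, bears on this change, and it showed no shift, so no movement beyond the scatter is expected in this assay; the expected step is no change at the digits printed from compound 2 to compound 3 (within the scatter). Compound 3 is therefore estimated at 2.9 ug/mL, with a range from 1.4 ug/mL to 6 ug/mL.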

Compound 3, concentration for half-maximal effect: 7.9 ug/mL
The estimate for compound 3 lay 2.7-fold (0.44 log units) below the measured number, outside the stated range (above it).
By their numbers in this assay, from the lowest: compounds 1 and 2 (each within the scatter of the next); then compound 3.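

In this assay the ring at this chain end does matter: furan-2-yl gives a 2.7-fold higher number from compound 2 to compound 3 (0.44 log units; beyond the scatter) and a 2.7-fold higher number from compound 1 to compound 3 (0.44 log units; beyond the scatter) so more compound is needed for the same effect. The two phenyl rings had stayed level, so this position tolerates some ring changes but not all. No measurement here explains the shift.

Going by these compounds alone, only one five-membered ring appears, so it remains open whether furan-2-yl is a special case or whether other five-membered rings read the same. Going by these compounds, how an amine or a carboxylic acid on the phenyl ring would read also remains open.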